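The compounds below may be only part of what the source reports. "The series", "measured", "known", "first", "only" and "open" are said of these compounds alone.

In a functional assay on PC-3 cells (Homo sapiens) for antiproliferative activity, read by WST assay, with a stated time of 3 days (on this read-out higher numbers stand for weaker inhibition and lower numbers for stronger inhibition), compound 2 `CCCN(CCC)CCCOc1c(-c2cc(OC)c(OC)c(OC)c2)oc2ccccc2c1=O` gives 16800 nM, the higher of the two numbers, and compound 1 `CCN(CC)CCCCCOc1c(-c2cc(OC)c(OC)c(OC)c2)oc2ccccc2c1=O` gives 6600 nM. The next change, to compound 3 `CCCCN(CCCC)CCCCCOc1c(-c2cc(OC)c(OC)c(OC)c2)oc2ccccc2c1=O`, is 2-(dibutylamino)ethyl in place of dipropylamino on a saturated chain carbon, three bonds along the chain from an oxygen on an aromatic ring. Going by the values given here, one measured step bears on this, a 2.5-fold higher number from compound 1 to compound 2 (0.41 log units; beyond the scatter), which is modest and made at the same place. Compound 1 carries 2-(diethylamino)ethyl there, so a reversal of similar modest size is expected in this assay, towards a lower number. The expected step is a 2.6-fold lower number from compound 2 to compound 3 (0.41 log units; beyond the scatter). Compound 3 is estimated at 6500 nM, with an expected range of 2500 nM to 16000 nM.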

Compound 3, half-maximal inhibitory concentration: 6800 nM
Beside the measured number, compound 3's estimate is 1.0-fold (0.02 log units) below it; the range from low to high includes it.
By their numbers in this assay, from the lowest: compounds 1 and 3 (each within the scatter of the next); then compound 2.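

With a 1.0-fold higher number from compound 1 to compound 3 (0.01 log units; within the scatter) as the step for dibutylamino in place of diethylamino, five bonds along the chain from an oxygen on an aromatic ring, these two amines are not told apart at this position. Going by these compounds alone, the step of a 2.5-fold lower number from compound 2 to compound 3 (0.39 log units; beyond the scatter) for 2-(dibutylamino)ethyl in place of dipropylamino therefore has no counterpart in the swap of dibutylamino for diethylamino. Still open, going by these compounds, is how a ring amine such as piperidine or morpholine, or a longer chain, would read at this position. No measurement on hand accounts for either step.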